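The compounds below may be only part of what the source reports. "The series", "measured", "known", "first", "only" and "open" are said of these compounds alone.

Measured so far:
compound 1 `CCOC(=O)c1cnc(C)nc1NN1C(=O)C=C(C)C1=O`: 16000 nM
compound 2 `CCOC(=O)c1cnc(-c2cc(Cl)nc(Cl)c2)nc1NN1C(=O)C=C(C)C1=O`: 2000 nM
compound 3 `CCOC(=O)c1cnc(C2CC2)nc1NN1C(=O)C=C(C)C1=O`: 1000 nM

In a functional assay on Jurkat cells for inhibition of nuclear factor NF-kappa-B complex (Homo sapiens) (on this read-out lower numbers stand for stronger inhibition and higher numbers for weaker inhibition), compound 2 gives 2000 nM, the second highest of the three numbers; compound 3 gives 1000 nM, differing by a 2.0-fold lower number from compound 2 to compound 3 (0.30 log units; within the scatter), while compound 1 gives 16000 nM, with an 8.0-fold lower number from compound 1 to compound 2 (0.90 log units; beyond the scatter). Compound 4 `CCOC(=O)c1cnc(S(=O)(=O)c2ccccc2)nc1NN1C(=O)C=C(C)C1=O` is not yet measured. The change: phenylsulfonyl in place of 2,6-dichloropyridin-4-yl on an aromatic carbon. Going by the values given here, the steps that bear on it all sit at the same aromatic carbon: an 8.0-fold lower number from compound 1 to compound 2 (0.90 log units; beyond the scatter) and a 16-fold lower number from compound 1 to compound 3 (1.20 log units; beyond the scatter) both leave methyl, whereas a 2.0-fold lower number from compound 2 to compound 3 (0.30 log units; within the scatter) swaps one larger group for another. Among the compounds with values here, because a 2.0-fold lower number from compound 2 to compound 3 (0.30 log units; within the scatter) is the only swap of 2,6-dichloropyridin-4-yl for another group and stayed within the scatter, no step beyond the scatter is expected for a 1.5-fold higher number from compound 2 to compound 4 (0.18 log units; within the scatter). Compound 4 is estimated at 3000 nM, range 800 nM to 12000 nM.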

Compound 4, half-maximal inhibitory concentration: 10000 nM
Compound 4: middle estimate off by 3.3-fold (0.52 log units), on the low side; the measured number falls inside the stated range.
By their numbers in this assay, from the lowest: compounds 3 and 2 (each within the scatter of the next); then compounds 4 and 1 (each within the scatter of the next).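

In this assay, larger groups on the aromatic carbon between two ring nitrogen atoms do not all read alike: a 5.0-fold higher number from compound 2 to compound 4 (0.70 log units; beyond the scatter) and a 10-fold higher number from compound 3 to compound 4 (1.00 log units; beyond the scatter) are both beyond the scatter. With a 1.6-fold lower number from compound 1 to compound 4 (0.20 log units; within the scatter), phenylsulfonyl is not separated from methyl, so compound 4 goes against any reading in which larger groups at this carbon give lower numbers than methyl. No measurement here accounts for the gap between phenylsulfonyl and the other two larger groups.

Open, from the compounds shown here alone, is whether the sulfonyl link or the phenyl ring carries this difference. Also open, going by these compounds, is how a directly attached phenyl, an amine or a longer alkyl chain on this carbon would read.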